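Selenium in Place of Sulfur: What Compound 4 May Show

The source may hold more compounds than are shown below. What is called first, only, known or untested is meant among the compounds shown, and "the series" means these compounds.

Compound 1 `CS/C(=N\C(=O)c1ccno1)NC(=O)c1ccno1` was examined in a functional assay on PC-3 cells (Homo sapiens) for cytotoxicity, read by MTT assay, with a stated time of 72 h; on this read-out higher numbers stand for lower toxicity in this test and lower numbers for higher toxicity in this test. In this assay compound 1 gives only the limit of > 100000 nM, a limit and not a number. Compound 2 `C[Se]/C(=N\C(=O)c1ccno1)NC(=O)c1ccno1` carries a group of 2 heavy atoms (1 carbon, 1 selenium; no ring) in place of a group of 2 heavy atoms (1 carbon, 1 sulfur; no ring), on a carbon with a double bond to nitrogen. In this assay compound 2 likewise reaches only the limit of > 100000 nM. The step from one to the other is a step that the two limits leave unreadable from compound 1 to compound 2; a reason cannot be given, since the whole evidence is the limit of > 100000 nM in this assay, at which 3 of the 3 values shown sit. Compound 3 `CS/C(=N\C(=O)c1cc(-c2ccccc2)nc2ccccc12)NC(=O)c1cc(-c2ccccc2)nc2ccccc12` rests on a different core, and the difference between the two cores is not broken down here. In this assay compound 3 also returns only the limit of > 100000 nM.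

The still unmeasured compound 4 `C[Se]/C(=N\C(=O)c1cc(-c2ccccc2)nc2ccccc12)NC(=O)c1cc(-c2ccccc2)nc2ccccc12` differs from compound 3 by a group of 2 heavy atoms (1 carbon, 1 selenium; no ring) in place of a group of 2 heavy atoms (1 carbon, 1 sulfur; no ring), on a carbon with a double bond to nitrogen, the same change as between compound 1 and compound 2, at the same place. For compound 4 the step is expected to be a step that the limit leaves unreadable from compound 3 to compound 4, an expectation that rests on the unreadable step from compound 1 to compound 2 and on the limits at which compound 1, compound 2 and compound 3 all sit. Compound 4 is therefore estimated at 150000 nM, most likely again only a limit, with a range from 30000 nM to 1000000 nM.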

Compound 4, concentration lethal to 50% of the cells: > 100000 nM
Compound 4: only a limit was reported (the forecaster's own chance of this, stated with the estimate: 85%); the middle value lies beyond the limit too.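

Compound 3 and compound 4 each return only a limit in this assay, so the change from methylsulfanyl to the selenium-bearing group yields no readable step between them. The compounds shown leave open whether this change alters toxicity on either core, and whether either core affects toxicity at all.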